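Pyrrolidinylmethyl in place of phenyl on a thiophene-fused core

This account rests on a few compounds, and the source may have more. Where it says the series, first, only, none or still open, it means among the compounds named here.

Compound 1 `O=C(Nc1ccc(C(=O)N2CCCN(Cc3ccccc3)c3sccc32)cc1)c1ccccc1-c1ccccc1` was tested in a functional assay on the whole organism for antagonist activity, with Rattus norvegicus as the target (a lower number here means that less compound is needed, a higher number that more compound is needed for the effect), and gave only a limit, > 0.3 mg/kg, so that its place is the edge of the assay itself (the limit of > 0.3 mg/kg in this assay, at which 1 of the 2 values shown sits). Compound 2 `CN(C)C1CCN(C(=O)CCCOc2cc(C(=O)N3CCCCc4sccc43)ccc2NC(=O)c2ccccc2-c2ccccc2)CC1`, which carries a different side chain, gives 0.005 mg/kg in this assay. Compound 3 `O=C(Nc1ccc(C(=O)N2CCCN(CCN3CCCC3)c3sccc32)cc1)c1ccccc1-c1ccccc1` differs from compound 1 by (pyrrolidin-1-yl)methyl in place of phenyl on a saturated chain carbon bound to a nitrogen on an aromatic ring in a ring. Among the compounds with values here, no measured pair shares this change, so the size of the step is unknown; the author expects it to move toward a lower number, beyond the usual scatter, as an at least 6.0-fold lower number from compound 1 to compound 3 (0.77 log units; beyond the scatter). Compound 3 is therefore estimated at 0.05 mg/kg, between 0.01 mg/kg and 0.5 mg/kg.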

Compound 3, dose for 50% inhibition: > 0.3 mg/kg
Compound 3: only a limit was reported; the forecaster's own chance of this, stated with the estimate: 25%; middle value at least 6.0-fold (0.77 log units) from the limit.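

Compound 1 and compound 3 each give only a limit in this assay, so no step can be read between them: the limit of > 0.3 mg/kg in this assay, at which 2 of the 3 values shown sit.

The compounds shown leave open whether (pyrrolidin-1-yl)methyl in place of phenyl changes the dose needed at all.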